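The compounds below may be only part of what the source reports. "The series", "measured", "known", "first", "only" and "open" are said of these compounds alone.

Working notes on the sulfonamide series in an ADME assay on HCT-116 cells (Homo sapiens) for cytotoxicity, read by CellTiter-Glo, with a stated time of 72 h; a higher number here means a weaker inhibitor, a lower number a stronger inhibitor.

Compound 1 `CC1CCN(C2CCN(S(=O)(=O)c3ccccc3-c3ccc(C(F)(F)F)cc3)CC2)CC1` carries a trifluoromethyl on its outer ring. In this assay compound 1 returns only a limit, > 5000 nM, and not a number. Compound 2 `CC1CCN(C2CCN(S(=O)(=O)c3ccccc3-c3ccc(Cl)cc3)CC2)CC1` differs from compound 1 by chloro in place of trifluoromethyl on an aromatic carbon. In this assay compound 2 likewise returns only a limit, > 5000 nM. The step that the two limits leave unreadable from compound 1 to compound 2 therefore cannot be read in size, because both ends sit at the limit of > 5000 nM in this assay, at which 3 of the 3 values shown sit.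

Compound 3 `CC1CCN(C2CCN(S(=O)(=O)c3ccc(Cl)c(C(F)(F)F)c3)CC2)CC1` belongs to a second core; the difference between the two cores is not broken down here. In this assay compound 3 also returns only a limit, > 5000 nM.

Compound 4 `CC1CCN(C2CCN(S(=O)(=O)c3ccc(Cl)c(Cl)c3)CC2)CC1` has not yet been run in this assay. It differs from compound 3 by chloro in place of trifluoromethyl on an aromatic carbon. This is the same kind of change as that from compound 1 to compound 2, but not the same: in the earlier pair the place is para to a large group, whereas here it is ortho to a chloro group and meta to a large group.

Within the data shown here, the expectation for compound 4 rests on (the limit of > 5000 nM in this assay, at which 3 of the 3 values shown sit), at which every value so far sits, and on the fact that the earlier change of the same kind left compound 2 at that limit. The step from compound 3 to compound 4 is expected to be a step that the limit leaves unreadable from compound 3 to compound 4. Compound 4 is estimated at 9000 nM in this assay, with a range from 3000 nM to 30000 nM, and most probably the assay will again report only a limit.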

Compound 4, half-maximal inhibitory concentration: > 5000 nM
Compound 4 ended at the assay's limit (the forecaster's own chance of this, stated with the estimate: 85%); the middle value does not contradict the limit.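

The size of the change from compound 3 to compound 4 cannot be read in this assay, because both compounds return a limit and not a number: the limit of > 5000 nM in this assay, at which 4 of the 4 values shown sit.

The compounds shown leave open how far each one lies from that limit, and whether chloro in place of trifluoromethyl on an aromatic carbon changes the read-out at either place.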